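Halogenated phenyl replaces dimethylphenyl on compound 1

The source may report more compounds than this note shows. Statements on the series, on what has been measured and on what is new or still open speak of the compounds shown alone.

Compound 1 `Cc1ccc(Nc2cc(NC(=O)Nc3c(Cl)cccc3Cl)ncn2)cc1C` was tested in a functional assay on NCI-H1581 cells (Homo sapiens) for inhibition, read by MTT assay, with a stated time of 48 h, tested at 10 uM (on this read-out lower numbers stand for less inhibition and higher numbers for more inhibition at the one concentration tested (going by the name of the read-out)), and gave 73.3%. Among the three compounds measured it stands highest, but compound 3 `COc1ccc(C(F)(F)F)cc1Nc1cc(NC(=O)Nc2c(Cl)cccc2Cl)ncn1`, which gave 69.1% in this assay, lies within the scatter of it, so the two cannot be told apart. Compound 2 `COc1cc(NC(=O)Nc2cc(Nc3cc(F)ccc3OC)ncn2)cc(OC)c1` is the only one clearly set off: in this assay compound 2 gives 42.1%, beyond the scatter below compound 1.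

Compound 4 `O=C(Nc1cc(Nc2ccc(F)c(Cl)c2)ncn1)Nc1c(Cl)cccc1Cl` has not yet been measured. It differs from compound 1 in one place: 3-chloro-4-fluorophenyl in place of 3,4-dimethylphenyl on a nitrogen on an aromatic ring. The rest of the molecule, including the part that compounds 1 and 3 share, is unchanged.

Among the measured compounds shown here, with no measured pair showing this exact change, the expectation rests on compounds 1 and 3, whose numbers sit together despite a different group on that nitrogen. The step from compound 1 to compound 4 is therefore expected to be a number 5.3 percentage points lower from compound 1 to compound 4 (within the scatter), small and not beyond the scatter in either direction. Compound 4 is estimated at 68% in this assay, with a range from 50% to 82%.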

Compound 4, a percentage reported as inhibition, at one concentration (the size of the read-out at that concentration, not a potency): 67%
Estimate against measurement, compound 4: 1 percentage points above, within the range that was stated.
By their numbers in this assay, from the lowest: compound 2; then compounds 4, 3 and 1 (each within the scatter of the next).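

In this assay, the exchange of 3,4-dimethylphenyl for 3-chloro-4-fluorophenyl on a nitrogen on an aromatic ring gives a number 6.3 percentage points lower from compound 1 to compound 4 (within the scatter), the first step read directly at this position. Both groups have 8 heavy atoms and one six-membered aromatic ring, and at this position the exchange of two methyl groups for chlorine and fluorine gives a compound that cannot be told apart from compound 1 at the one concentration tested. The data shown offer no measurement that explains this result.

Still open, going by these compounds, is whether the number would hold with a group of another kind on that nitrogen, such as a pyridine or a short alkyl chain. Compound 2 differs from compound 1 in more than one place, so its lower number cannot be traced to any single part.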